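The compounds below may be only part of what the source reports. "The series", "measured", "known", "first", "only" and "open" are said of these compounds alone.

Measured so far:
compound 1 `CN1CCN(c2nc(-c3ccc(Cl)c(Cl)c3)nc3[nH]cnc23)CC1` — 24.1%
compound 2 `Clc1ccc(-c2nc(N3CCCCC3)c3nc[nH]c3n2)cc1Cl` — 0.7%

In an assay on cells for displacement of a labelled ligand from adenosine receptor A2b (Homo sapiens), read by scintillation counting and radioligand binding, with a stated time of 30 min, tested at 10 uM (a higher number here means more inhibition at the concentration tested (going by the name of the read-out), a lower number less inhibition), compound 1 gives 24.1%, the higher of the two numbers; compound 2 gives 0.7%, and the step of a number 23.4 percentage points lower from compound 1 to compound 2 (beyond the scatter) concerns the amine on the shared core, not the aryl ring. Compound 3 `CN1CCN(c2nc(-c3ccc(Cl)c(C(F)(F)F)c3)nc3[nH]cnc23)CC1` differs from compound 1 by trifluoromethyl in place of chloro on an aromatic carbon. Within the data shown here, no measured step touches this position, so nothing predicts its size or direction; the expected step of a number 4.1 percentage points lower from compound 1 to compound 3 (within the scatter) is therefore taken as small, not beyond the scatter. Compound 3 is estimated at 20%, with a range of 5% to 40%.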

Compound 3, a percentage reported as inhibition, at one concentration (the size of the read-out at that concentration, not a potency): 25.1%
Compound 3: middle estimate off by 5.1 percentage points, on the low side, and the stated range covers the measured number.
By their numbers in this assay, from the lowest: compound 2; then compounds 1 and 3 (each within the scatter of the next).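

In this assay, among these compounds, trifluoromethyl in place of chloro on an aromatic carbon, ortho to a chloro group, gives a number 1 percentage points higher from compound 1 to compound 3 (within the scatter), the first measured step on the aryl ring rather than at the amine. This exchange therefore does not separate the two compounds, whereas the amine change gives a number 23.4 percentage points lower from compound 1 to compound 2 (beyond the scatter). No measured evidence bears on this result.

From the compounds shown here alone, whether a nitrile, a methoxy group or hydrogen at this position would also leave the number within the scatter remains open. Also open, going by these compounds, is how trifluoromethyl behaves alongside piperidin-1-yl on the shared core.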